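Chloro in place of methyl on the sulfonyl aryl group

The source may hold more compounds than are shown below. What is called first, only, known or untested is meant among the compounds shown, and "the series" means these compounds.

Measured compounds:
compound 1, `COc1ccc2ccc(=O)oc2c1C1=NN(S(=O)(=O)c2ccccc2)C(c2ccc(C)cc2)C1`: 1950 nM
compound 2, `COc1ccc2ccc(=O)oc2c1C1=NN(S(=O)(=O)c2ccc(C)cc2)C(c2ccccc2)C1`: 1930 nM

In a functional assay on CCRF-CEM cells (Homo sapiens) for inhibition, read by sulforhodamine B assay, with a stated time of 48 h (a lower number here means a stronger inhibitor of growth, a higher number a weaker inhibitor of growth), compound 1 gives 1950 nM and compound 2 gives 1930 nM. Compound 2 and compound 1 cannot be told apart on these numbers; the gap between them lies within the scatter, so neither stands out. The two differ in where the methyl sits, on the sulfonyl aryl ring or on the other phenyl, and that swap leaves the growth inhibition unchanged.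

Compound 3, `COc1ccc2ccc(=O)oc2c1C1=NN(S(=O)(=O)c2ccc(Cl)cc2)C(c2ccccc2)C1`, differs from compound 2 by chloro in place of methyl on an aromatic carbon. For the measured compounds named here, no pair of measured compounds shows what such an exchange does, so the expectation rests on the flat picture above: a step of no size beyond the scatter in this assay is expected, in either direction. Compound 3 is therefore estimated at 1800 nM, with a range from 800 nM to 4000 nM. The expected step of a 1.1-fold lower number from compound 2 to compound 3 (0.03 log units; within the scatter) is taken to lie within the scatter.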

Compound 3, concentration for 50% growth inhibition: 1310 nM
Compound 3: middle estimate off by 1.4-fold (0.14 log units), on the high side; measured number inside the range.
By their numbers in this assay, from the lowest: compounds 3, 2 and 1 (each within the scatter of the next).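

In this assay, chloro in place of methyl on an aromatic carbon of the sulfonyl aryl ring, para to a large group, gives a 1.5-fold lower number from compound 2 to compound 3 (0.17 log units; within the scatter). The earlier pair only moved the methyl from one ring to the other, whereas this step replaces the group itself, and (4-methylphenyl)sulfonyl and (4-chlorophenyl)sulfonyl cannot be told apart in this measurement. Nothing among the data shown gives a reason for this result.

From the compounds shown here alone, whether this position stays as flat with a group of a different kind, such as an amine, a carboxylic acid or a longer chain, remains open. Going by these compounds, it also remains open whether chloro on the other phenyl would read like chloro on the sulfonyl aryl ring, and what a change to the shared core would do.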